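Swapping Isopropyl for Cyclopropyl on a Sulfonyl Sulfur

The source may hold more compounds than are shown below. What is called first, only, known or untested is meant among the compounds shown, and "the series" means these compounds.

Measured compounds:
- Compound 1, `O=C([C@@H]1CCCN(S(=O)(=O)c2ccc(S(=O)(=O)C3CCC3)cc2)C1)N1CCC(F)(F)CC1`, gives 9 nM in a functional assay on MIA PaCa-2 cells (Homo sapiens) for inhibition, read by MTT assay, with a stated time of 7 days; a higher number here means a weaker inhibitor, a lower number a stronger inhibitor.
- Compound 2, `O=C([C@@H]1CCCN(S(=O)(=O)c2ccc(S(=O)(=O)C3COC3)cc2)C1)N1CCC(F)(F)CC1`, gives 110 nM in this assay.
- Compound 3, `CC(C)S(=O)(=O)c1ccc(S(=O)(=O)N2CCC[C@@H](C(=O)N3CCC(F)(F)CC3)C2)cc1`, gives 11 nM in this assay.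

Three compounds share one core and differ only in the group on a sulfonyl sulfur. Compound 3 stands second of the three numbers: its nearest neighbour is compound 1, with a 1.2-fold higher number from compound 1 to compound 3 (0.09 log units; within the scatter), a gap that stays within the scatter, and its furthest is compound 2, with a 10-fold lower number from compound 2 to compound 3 (1.00 log units; beyond the scatter), which lies beyond it.

Compound 4, `O=C([C@@H]1CCCN(S(=O)(=O)c2ccc(S(=O)(=O)C3CC3)cc2)C1)N1CCC(F)(F)CC1`, has not yet been measured. It differs from compound 3 in one place: cyclopropyl in place of isopropyl on a sulfonyl sulfur. The group that leaves and the group that enters carry the same count of carbon atoms and no oxygen; the only new feature is a small carbon ring.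

Two measured steps speak to this. The change from cyclobutyl to isopropyl, a 1.2-fold higher number from compound 1 to compound 3 (0.09 log units; within the scatter), shows that exchanging one all-carbon group for another of similar size left the number essentially unchanged. The large shift seen in a 12-fold higher number from compound 1 to compound 2 (1.09 log units; beyond the scatter) came with an oxygen-containing ring, which compound 4 does not have. On that basis no step beyond the scatter is expected: the estimated change for compound 4 is a 1.1-fold higher number from compound 3 to compound 4 (0.04 log units; within the scatter), with an expected value of 12 nM and a likely range from 5 nM to 40 nM.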

Compound 4, half-maximal inhibitory concentration: 26 nM
Compound 4: the middle estimate sits 2.2-fold (0.34 log units) below what was measured; measured number inside the range.
By their numbers in this assay, from the lowest: compounds 1 and 3 (each within the scatter of the next); then compound 4; then compound 2.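

Among groups made only of carbon, this position is more sensitive than the earlier compounds suggested. Closing isopropyl into cyclopropyl keeps the carbon count at three, yet in this assay it gives a 2.4-fold higher number from compound 3 to compound 4 (0.37 log units; beyond the scatter) and so moves the number beyond the scatter, while the same group in place of cyclobutyl gives a 2.9-fold higher number from compound 1 to compound 4 (0.46 log units; beyond the scatter) on the same scale. Having a carbon ring is therefore not enough on its own to shift the number, since cyclobutyl and isopropyl sit within the scatter of each other, and the oxygen-containing ring remains the weakest group shown, with cyclopropyl in its place giving a 4.2-fold lower number from compound 2 to compound 4 (0.63 log units; beyond the scatter) in this series.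

Nothing shown here explains why the three-membered ring stands apart from cyclobutyl and isopropyl.

Also open, on these data alone, is how larger or differently built groups on this sulfonyl sulfur would behave, such as cyclopentyl, tert-butyl or a ring carrying an amine, and so whether cyclopropyl is an isolated dip or part of a trend with ring size.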